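Compound 2 to compound 4: a chloropyridinyl exchange

The source may hold more compounds than are shown below. What is called first, only, known or untested is meant among the compounds shown, and "the series" means these compounds.

Measured so far in a functional assay on A-375 cells (Homo sapiens) for antiproliferative activity, read by MTT assay, with a stated time of 48 h; on this read-out lower numbers stand for stronger inhibition and higher numbers for weaker inhibition:
compound 1 `O=C(Nc1cc(-c2ccccc2)[nH]n1)c1cccnc1Cl`: 7340 nM
compound 2 `Cc1ccc(-c2cc(NC(=O)c3cccnc3Cl)n[nH]2)cc1`: 6440 nM
compound 3 `COc1ncccc1C(=O)Nc1cc(-c2ccc(C)cc2)[nH]n1`: 8730 nM

Compound 2, at 6440 nM, cannot be separated from either of its two neighbours in the series. The step that leads to it is a 1.1-fold lower number from compound 1 to compound 2 (0.06 log units; within the scatter), and the step that leads away from it is a 1.4-fold higher number from compound 2 to compound 3 (0.13 log units; within the scatter). Within the data shown here, on these numbers it stands level with both, and the series so far shows a flat profile.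

The next compound is compound 4 `Cc1ccc(-c2cc(NC(=O)c3ccc(Cl)nc3)n[nH]2)cc1`, which has not yet been measured in this assay. It carries 6-chloropyridin-3-yl in place of 2-chloropyridin-3-yl on a carbonyl carbon. The two compounds have the same atoms, joined differently.

Among the measured compounds shown here, no measured step makes this exact exchange, so the evidence is indirect. The closest is the change on the same ring from compound 2 to compound 3, a 1.4-fold higher number from compound 2 to compound 3 (0.13 log units; within the scatter), where methoxy replaces chloro. The change on the other side of the molecule, a 1.1-fold lower number from compound 1 to compound 2 (0.06 log units; within the scatter), is equally small. Neither offers a reason to expect a direction, so no step beyond the scatter is expected, though the data leave this exchange untested.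

The expected outcome is a 1.0-fold higher number from compound 2 to compound 4 (0.00 log units; within the scatter). For compound 4 the estimated value is 6500 nM, with an expected range from 2500 nM to 15000 nM.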

Compound 4, half-maximal inhibitory concentration: 6880 nM
The estimate for compound 4 lay 1.1-fold (0.02 log units) below the measured number; low and high end bracket the measured number.
By their numbers in this assay, from the lowest: compounds 2, 4, 1 and 3 (each within the scatter of the next).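

In this assay, the exchange of 2-chloropyridin-3-yl for 6-chloropyridin-3-yl on a carbonyl carbon, with an amide-type nitrogen as its other neighbour, amounts to a 1.1-fold higher number from compound 2 to compound 4 (0.03 log units; within the scatter) and so gives no readable change. The earlier steps shown here had swapped one group for a different one, whereas this step keeps the same atoms and joins them differently, so it shows that at this place a rearrangement of the chloropyridinyl group also leaves the flat profile of the series intact, with all four compounds still forming a chain in which each lies within the scatter of the next. No measurement at hand offers an explanation for this result.

What stays open is whether this place can respond at all, since the groups shown on the pyridinyl ring are limited to chloro and methoxy, and an amine or a carboxylic acid there might or might not move the number beyond the scatter. As far as these compounds go, it is equally open whether a longer chain in place of the methyl on the other side of the shared core would produce a step that can be read.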